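Chloro in place of fluoro on a triazole-linked aryl ring

This account rests on a few compounds, and the source may have more. Where it says the series, first, only, none or still open, it means among the compounds named here.

Of the compounds shown here, two sharing one core have been measured in a functional assay on MCF7 cells (Homo sapiens) for cytotoxicity, read by MTT assay, with a stated time of 4 days; on this read-out lower numbers stand for stronger inhibition and higher numbers for weaker inhibition. Compound 1 `C=C1C(=O)[C@]23C[C@@]1(O)CC[C@H]2c1ccc(OS(=O)(=O)c2ccc(C)cc2)c(C)c1[C@@H]3Cn1cc(-c2ccc(Cl)cc2)nn1` gives 1440 nM in this assay. Compound 2 `C=C1C(=O)[C@]23C[C@@]1(O)CC[C@H]2c1ccc(O)c(C)c1[C@@H]3Cn1cc(-c2ccc(F)cc2)nn1` gives 1700 nM in this assay, the higher of the two numbers, yet its gap to compound 1 lies within the usual scatter, so the two cannot be ranked against each other. For the measured compounds named here, compound 1 and compound 2 differ in more than one place, so their two values show no single step.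

Compound 3 `C=C1C(=O)[C@]23C[C@@]1(O)CC[C@H]2c1ccc(O)c(C)c1[C@@H]3Cn1cc(-c2ccc(Cl)cc2)nn1` has not yet been measured. It differs from compound 2 by chloro in place of fluoro on an aromatic carbon. Going by the values given here, no pair of measured compounds isolates this change: compound 1 also carries the chlorophenyl group, but together with a further difference, so its value is no clean guide. The step from compound 2 to compound 3 in this assay is expected to be a 1.2-fold lower number from compound 2 to compound 3 (0.08 log units; within the scatter), not beyond the scatter, tending if anything toward a somewhat lower number. Compound 3 is therefore estimated at 1400 nM, with a range from 700 nM to 2800 nM.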

Compound 3, half-maximal inhibitory concentration: 2470 nM
The estimate for compound 3 lay 1.8-fold (0.25 log units) below the measured number; low and high end bracket the measured number.
By their numbers in this assay, from the lowest: compounds 1, 2 and 3 (each within the scatter of the next).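

In this assay the change from 4-fluorophenyl to 4-chlorophenyl can now be read on its own, with the free hydroxyl on the aromatic ring of the shared core held constant: it gives a 1.5-fold higher number from compound 2 to compound 3 (0.16 log units; within the scatter) and so does not separate the two halogens at this aromatic carbon, para to a large group. For the compounds shown here, compound 3 also gives the first single-place reading at the oxygen on the aromatic ring, where the step to hydrogen from (4-methylphenyl)sulfonyl, with the 4-chlorophenyl group held constant, is a 1.7-fold higher number from compound 1 to compound 3 (0.23 log units; within the scatter), so this bulky group on that oxygen and a plain hydrogen cannot be told apart in this assay either. No measurement available here bears on these two results.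

The compounds shown leave open whether a bromo, a methoxy or an amine on that same aromatic carbon would give a step beyond the scatter, and whether a methyl or an acetyl on the oxygen would do so. They also leave open whether the step from fluoro to chloro would read the same with the (4-methylphenyl)sulfonyl group in place on the oxygen.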